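The compounds below may be only part of what the source reports. "The series", "measured", "known", "first", "only" and "open" are said of these compounds alone.

In an assay on isolated protein for inhibition of Amine oxidase [flavin-containing] B (Homo sapiens) (on this read-out higher numbers stand for weaker inhibition and lower numbers for stronger inhibition), the three compounds measured so far stand as follows:

- compound 1 `C#CCNC1CCc2c(SCc3ccc4ccccc4c3)cccc21` gives 4950 nM
- compound 2 `C#CCNC1CCc2c(SCc3cccc(C)c3)cccc21` gives > 100000 nM
- compound 3 `C#CCNC1CCc2c(SCCc3cccc(Br)c3)cccc21` gives 30500 nM

The three share a core and differ only in the group carried on the sulfur. Compound 1 and compound 3 each give a number in this assay. Among the measured compounds shown here, compound 2 does not: its value of > 100000 nM is a limit of the assay, not a measured number, so it is known only that compound 2 sits at the limit of > 100000 nM in this assay, at which 1 of the 3 values shown sits, and no closer figure exists for it.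

The next compound, compound 4 `C#CCNC1CCc2c(SCc3cccc(OC)c3)cccc21`, differs from compound 2 in one place: methoxy in place of methyl on an aromatic carbon. For the measured compounds named here, no two measured compounds differ in exactly this way, so nothing measured here shows what this exchange does. The expectation for the step from compound 2 to compound 4 is therefore wide: an at least 1.2-fold lower number from compound 2 to compound 4 (0.09 log units; that floor lies within the scatter) is expected, which may be no change beyond the scatter, with the chance that compound 4 again reaches only a limit kept in view. Compound 4 is estimated at 80000 nM, within 20000 nM to 300000 nM.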

Compound 4, half-maximal inhibitory concentration: 3190 nM
The estimate for compound 4 lay 25-fold (1.40 log units) above the measured number; measured number outside the range, below it.
By their numbers in this assay, from the lowest: compounds 4 and 1 (each within the scatter of the next); then compound 3. At a limit, above all of these: compound 2.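

On this aromatic carbon, meta to a large group, methoxy in place of methyl gives an at least 31-fold lower number from compound 2 to compound 4 (1.49 log units; beyond the scatter). This is the first exchange shown at a single place on the shared core, and it shows that the read-out in this assay can respond strongly to a change of one small group on this ring. The step can be given only as a minimum because compound 2 has a limit of the assay rather than a number: the limit of > 100000 nM in this assay, at which 1 of the 4 values shown sits.

With only one exchange shown at this carbon, it remains open whether a hydroxyl, an ethoxy or an amine there would also give a lower number than the methyl. As far as these compounds go, it is also open whether methoxy would give a step of similar size on the longer chain of compound 3.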